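This account rests on a few compounds, and the source may have more. Where it says the series, first, only, none or still open, it means among the compounds named here.

Measured so far in a functional assay on HeLa cells (Homo sapiens) for antiproliferative activity, with a stated time of 24 h; on this read-out lower numbers stand for stronger inhibition and higher numbers for weaker inhibition:
compound 1 `NC(=O)c1c(NC(=O)c2ccccc2Cl)sc2c1CCN(Cc1c(Cl)cccc1Cl)C2` gives 28800 nM
compound 2 `NC(=O)c1c(NC(=O)c2ccccc2Cl)sc2c1CCN(Cc1ccc(Cl)cc1Cl)C2` gives 21100 nM
compound 3 `NC(=O)c1c(NC(=O)c2ccc(C(F)(F)F)cc2)sc2c1CCN(Cc1c(Cl)cccc1Cl)C2` gives > 50000 nM

The value of compound 3 is a limit of this assay, not a number; it sits at the limit of > 50000 nM in this assay, at which 1 of the 3 values shown sits.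

Compounds 1 and 2 share a core and differ only in 2,4-dichlorophenyl in place of 2,6-dichlorophenyl on a saturated chain carbon bound to an amine nitrogen in a ring. That change gave a 1.4-fold lower number from compound 1 to compound 2 (0.14 log units; within the scatter). The core of compound 3 differs from that of compound 1 by 4-(trifluoromethyl)phenyl in place of 2-chlorophenyl on a carbonyl carbon, a change that gave an at least 1.7-fold higher number from compound 1 to compound 3 (0.23 log units; that floor lies within the scatter).

Compound 4 `NC(=O)c1c(NC(=O)c2ccc(C(F)(F)F)cc2)sc2c1CCN(Cc1ccc(Cl)cc1Cl)C2` is not yet measured. It differs from compound 3 by 2,4-dichlorophenyl in place of 2,6-dichlorophenyl on a saturated chain carbon bound to an amine nitrogen in a ring, the same change as that between compounds 1 and 2, at the same place. Since the earlier step from compound 1 to compound 2 lay within the scatter, the corresponding step from compound 3 to compound 4 is expected to do the same, that is, roughly a number no higher from compound 3 to compound 4 (the limit leaves the size open), with the starting point already a limit. Compound 4 is therefore estimated at 50000 nM in this assay, within 25000 nM to 120000 nM, and it is expected that the assay may again report only a limit rather than a number.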

Compound 4, half-maximal inhibitory concentration: > 50000 nM
Compound 4 was reported as a limit (the forecaster's own chance of this, stated with the estimate: 65%); the middle value sits exactly at the limit.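

In this assay the step from compound 3 to compound 4 cannot be read: both values are limits. The change from 2-chlorophenyl to 4-(trifluoromethyl)phenyl on a carbonyl carbon, carried to the core of compound 2, gives an at least 2.3-fold higher number from compound 2 to compound 4 (0.37 log units; beyond the scatter) and so shows a higher number on that core, with only a floor for its size. This does not give the true size of the change on either core, and no claim can be made that it carries over unchanged or differs between the two cores: the same change on two cores in this assay, an at least 1.7-fold higher number (0.23 log units; that floor lies within the scatter) from compound 1 to compound 3 and an at least 2.3-fold higher number (0.37 log units; beyond the scatter) from compound 2 to compound 4; the limit leaves it open whether they differ.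

The compounds shown leave open how 2,4-dichlorophenyl and 2,6-dichlorophenyl compare when 4-(trifluoromethyl)phenyl sits on the carbonyl carbon. They also leave open whether a phenyl carrying a nitrile, an amine or a carboxylic acid on that carbon would give a readable number in place of a limit.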